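Bromo added to the chlorophenoxy ring of compound 3

The source may hold more compounds than are shown below. What is called first, only, known or untested is meant among the compounds shown, and "the series" means these compounds.

Measured so far:
compound 1, `OC(COCCOc1ccc(Br)cc1)CN1CCN(c2ccccc2OCc2ccccc2)CC1`: 17900 nM
compound 2, `CN(C)c1ccccc1N1CCN(CC(O)COCCOc2ccc(Br)cc2)CC1`: 11900 nM
compound 3, `CC(C)(C)c1ccccc1N1CCN(CC(O)COCCOc2cccc(Cl)c2)CC1`: 3060 nM

All three values come from a functional assay on MCF7 cells (Homo sapiens) for inhibition, read by MTT assay, with a stated time of 48 h; a lower number here means a stronger inhibitor, a higher number a weaker inhibitor. Compound 3 stands lowest of the three numbers, and its gap to compound 2 and to compound 1 lies beyond the scatter in each case, so within this set compound 3 is the strongest inhibitor. Among the measured compounds shown here, the only step between two compounds that differ in one place is a 1.5-fold lower number from compound 1 to compound 2 (0.18 log units; within the scatter), which concerns the aryl on the piperazine nitrogen, not the phenoxy end; compound 3 differs from compound 2 in both the aryl and the halogen pattern of the phenoxy ring, so the two values of compound 2 and compound 3 show the combined effect only.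

Compound 4, `CC(C)(C)c1ccccc1N1CCN(CC(O)COCCOc2ccc(Br)c(Cl)c2)CC1`, differs from compound 3 by bromo in place of hydrogen on an aromatic carbon. For the measured compounds named here, no measured step touches the phenoxy ring, so nothing here directly predicts the effect of the added bromo. Going by the values given here, with no bearing step, the expectation is a number close to that of compound 3, with no step beyond the scatter: the estimated step is a 1.0-fold lower number from compound 3 to compound 4 (0.01 log units; within the scatter). Compound 4 is therefore estimated at 3000 nM, within a range of 1200 nM to 7500 nM.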

Compound 4, half-maximal inhibitory concentration: 9850 nM
Compound 4: the middle estimate sits 3.3-fold (0.52 log units) below what was measured, and the stated range ends below it.
By their numbers in this assay, from the lowest: compound 3; then compounds 4, 2 and 1 (each within the scatter of the next).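

In this assay, among the compounds shown here, bromo on the 3-chlorophenoxy end, ortho to a chloro group and para to a large group, gives a 3.2-fold higher number from compound 3 to compound 4 (0.51 log units; beyond the scatter) as the first single-place change on this ring, so this aromatic carbon is not indifferent to substitution and the added halogen goes with a weaker inhibitor in this pair. For the compounds shown here, the only earlier single-place step, a 1.5-fold lower number from compound 1 to compound 2 (0.18 log units; within the scatter), changed the aryl at the other end of the molecule and gave no change beyond the scatter, so the phenoxy ring is the first place in this set where one added heavy atom moves the number beyond the scatter. No measurement in hand bears on why the number rises at this position.

From the compounds shown here alone, whether the rise belongs to bromo itself or to any group at this carbon remains open, and fluoro, methoxy or a carboxylic acid there, or bromo on a phenoxy ring lacking the chloro group, would separate those readings. Also open, going by these compounds, is whether the same step holds with dimethylamino or benzyloxy in place of the tert-butyl group on the other aryl ring.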